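Series notes: from compound 3 to compound 4

The source may report more compounds than this note shows. Statements on the series, on what has been measured and on what is new or still open speak of the compounds shown alone.

The three measured compounds share one core and differ only in the aromatic group carried on the five-membered aromatic ring with 4 nitrogen. Compound 1 `Cc1cc(NC(=O)Cn2nnc(-c3ccccn3)n2)n(C2CCCCC2)n1` gives 81% in an assay on HEK293 cells for activation of Kir3.1/Kir3.2 (Homo sapiens), read by thallium flux; on this read-out higher numbers stand for larger maximal responses and lower numbers for smaller maximal responses. Compound 2 `Cc1cc(NC(=O)Cn2nnc(-c3cc(Cl)cc(Cl)c3)n2)n(C2CCCCC2)n1` gives 82% in this assay. Compound 3 `Cc1cccc(-c2nnn(CC(=O)Nc3cc(C)nn3C3CCCCC3)n2)c1` gives 93% in this assay, the highest of the three numbers; its margins over the other two are a number 12 percentage points higher from compound 1 to compound 3 (beyond the scatter) and a number 11 percentage points higher from compound 2 to compound 3 (beyond the scatter), both beyond the scatter, while a number 1 percentage points higher from compound 1 to compound 2 (within the scatter) stays within it.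

Compound 4 `COc1ccc(-c2nnn(CC(=O)Nc3cc(C)nn3C3CCCCC3)n2)cc1` is not yet measured. Compared with compound 3 the difference is 4-methoxyphenyl in place of 3-methylphenyl on an aromatic carbon.

All three measured steps bear on this position, since each exchanges the aromatic group there: two were modest and beyond the scatter, the third within it. Exchanging the aromatic group at this place has so far moved the maximal response only modestly. Compound 3 stands at the top of the range seen, and its closest analogues sit lower, so for compound 4 a step of no more than modest size is expected in this assay, more likely downward than upward, and possibly within the scatter.

Compound 4 is therefore expected to give 85% in this assay, with a range from 70% to 98%. This estimate means an expected step of a number 8 percentage points lower from compound 3 to compound 4 (within the scatter).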

Compound 4, largest response reached (Emax), in percent of the reference or control that the assay uses: 90%
Estimate against measurement, compound 4: 5 percentage points below; measured number inside the range.
By their numbers in this assay, from the lowest: compounds 1, 2, 4 and 3 (each within the scatter of the next, the first and the last beyond it).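

In this assay, 4-methoxyphenyl in place of 3-methylphenyl on the aromatic carbon of the five-membered aromatic ring with 4 nitrogen gives a number 3 percentage points lower from compound 3 to compound 4 (within the scatter), so this position accepts an entering group that carries a hydrogen-bond acceptor, where the leaving group carries none, without a step beyond the scatter. The other two new steps, a number 8 percentage points higher from compound 2 to compound 4 (within the scatter) and a number 9 percentage points higher from compound 1 to compound 4 (within the scatter), also stay within the scatter, so compound 4 cannot be separated from any of the other three compounds, even though compound 3 stands beyond the scatter from compound 1 and compound 2. No measurement shown here explains these small steps at this position.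

The exchange of 3-methylphenyl for 4-methoxyphenyl alters both the substituent and the place it occupies on the phenyl ring, and the compounds shown cannot separate those two changes. Going by these compounds, it also remains open how the maximal response would move with an amine or a carboxylic acid on that phenyl ring, or with a saturated group such as cyclohexyl in place of the aromatic group at this position.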